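Arylmethyl ether variation at the aromatic oxygen: compound 3

The source may hold more compounds than are shown below. What is called first, only, known or untested is meant among the compounds shown, and "the series" means these compounds.

compound 1 `COc1ccc2c(=O)c(-c3cc(OC)c(OC)cc3OC)coc2c1` — > 10000 nM
compound 2 `COc1cc(OC)c(-c2coc3cc(OCc4ccc(C#N)cc4)ccc3c2=O)cc1OC` — > 10000 nM

In a functional assay on HUVEC cells (Homo sapiens) for antiproliferative activity, read by MTT assay, with a stated time of 24 h (a lower number here means a stronger inhibitor, a higher number a weaker inhibitor), compound 1 gives > 10000 nM, which is a limit of the assay and not a number. In this assay compound 2 likewise gives > 10000 nM, again a limit. Compound 1 thus stands only at a limit, with no measured number to place it against. The change to compound 3 `COc1cc(OC)c(-c2coc3cc(OCc4cccc(Br)c4)ccc3c2=O)cc1OC` is 3-bromophenyl in place of hydrogen on a saturated chain carbon bound to an oxygen on an aromatic ring. Among the measured compounds shown here, the only measured step of the same kind, a step that the two limits leave unreadable from compound 1 to compound 2, is unreadable since the limit of > 10000 nM in this assay, at which 2 of the 2 values shown sit, fixes both ends of it. For the measured compounds named here, no measured step therefore tells the direction or size of the change to compound 3. The step is estimated as a step that the limit leaves unreadable from compound 1 to compound 3, expected to be none beyond the scatter, the likely outcome being another limit. Compound 3 is estimated at 15000 nM, in the range 4000 nM to 60000 nM, most probably reported only as a limit.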

Compound 3, half-maximal inhibitory concentration: > 10000 nM
Compound 3 ended at the assay's limit; the forecaster's own chance of this, stated with the estimate: 80%; the middle value lies beyond the limit too.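

No step among compound 1, compound 2 and compound 3 can be read, since all three stand at one limit and not at a number: the limit of > 10000 nM in this assay, at which 3 of the 3 values shown sit.

Still open, as far as these compounds go, is whether the 4-cyanophenyl or 3-bromophenyl group changes the activity of compound 1 at all in this assay, and in which direction.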